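The source may report more compounds than this note shows. Statements on the series, on what has been measured and on what is new or still open speak of the compounds shown alone.

Measured compounds and their values:
compound 1, `COc1ccc([C@H]2CC(c3cc4ccccc4oc3=O)=NN2c2ccccc2)cc1` — 24.8%
compound 2, `O=c1oc2ccccc2cc1C1=NN(c2ccccc2)[C@@H](c2ccc(Cl)cc2)C1` — 39.2%
compound 3, `Cc1ccc([C@H]2CC(c3cc4ccccc4oc3=O)=NN2c2ccccc2)cc1` — 30.1%

All three numbers come from a functional assay on the whole organism (strain albino) for inhibition, with Rattus norvegicus as the target, read by paw edema, with stated times of 1 h and 2 h, at a dose of 200 mg/kg by the oral route; a lower number here means less inhibition, a higher number more inhibition at the dose given (going by the name of the read-out). Compound 3 stands second highest of the three, but neither of its gaps to the others is beyond the scatter: a number 5.3 percentage points higher from compound 1 to compound 3 (within the scatter) and a number 9.1 percentage points lower from compound 2 to compound 3 (within the scatter) both lie within it. Only a number 14.4 percentage points higher from compound 1 to compound 2 (beyond the scatter) goes beyond the scatter, and that step does not involve compound 3.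

Compound 4, `COc1cccc([C@H]2CC(c3cc4ccccc4oc3=O)=NN2c2ccccc2)c1`, differs from compound 3 by 3-methoxyphenyl in place of 4-methylphenyl on a saturated ring carbon. The measured step that bears most directly on this change is a number 5.3 percentage points higher from compound 1 to compound 3 (within the scatter), run in reverse, since methoxy again takes the place of methyl, though in compound 4 the methoxy enters as 3-methoxyphenyl rather than as the group carried by compound 1. That step was within the scatter. Among the compounds with values here, no other measured step exchanges methoxy for methyl. The expectation for this assay is therefore a step of no more than the scatter, in either direction, with a slight lean toward the value of compound 1. For compound 4 the estimated value is 27%, in a range from 17% to 38%. The expected step is accordingly a number 3.1 percentage points lower from compound 3 to compound 4 (within the scatter), within the scatter.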

Compound 4, a percentage reported as inhibition, in the whole organism at one dose (the size of the read-out at that dose, not a potency): 38.3%
Estimate against measurement, compound 4: 11.3 percentage points below; measured number outside the range, above it.
By their numbers in this assay, from the lowest: compounds 1, 3, 4 and 2 (each within the scatter of the next, the first and the last beyond it).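

Within the data shown here, compound 4 gives the first comparison of one substituent in two placements on the phenyl group at this saturated ring carbon: with 3-methoxyphenyl in place of 4-methoxyphenyl, this assay shows a number 13.5 percentage points higher from compound 1 to compound 4 (beyond the scatter), so the placement of the methoxy changes the reading in this pair. The other two steps, a number 8.2 percentage points higher from compound 3 to compound 4 (within the scatter) and a number 0.9 percentage points lower from compound 2 to compound 4 (within the scatter), leave 3-methoxyphenyl indistinguishable from 4-methylphenyl and from 4-chlorophenyl. Nothing available here bears on what lies behind the difference between the two methoxyphenyl compounds.

From the compounds shown here alone, whether the same shift in placement would hold for 3-chlorophenyl or 3-methylphenyl remains open. Also open, going by these compounds, is how an aminophenyl or a carboxyphenyl group would read at this ring carbon, and a single oral dose leaves potency undefined.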